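The source may report more compounds than this note shows. Statements on the series, on what has been measured and on what is new or still open speak of the compounds shown alone.

Working notes on the series. In a functional assay on MCF7 cells (Homo sapiens) for inhibition, read by sulforhodamine B assay, with a stated time of 48 h (a higher number here means a weaker inhibitor of growth, a lower number a stronger inhibitor of growth), compound 1 `N#Cc1c(-c2nnc(-c3ccccc3)c3nn(-c4ccccc4)cc23)nn(-c2ccccc2)c1-c1ccccc1` gives 9530 nM. Compound 2 `N#Cc1c(-c2nnc(-c3ccccc3)c3nn(-c4ccc(Cl)cc4)cc23)nn(-c2ccccc2)c1-c1ccccc1` gives 43800 nM, the higher of the two numbers and so the weaker inhibitor of growth so far. Among the compounds with values here, the only measured step is a 4.6-fold higher number from compound 1 to compound 2 (0.66 log units; beyond the scatter), a modest one, for chloro in place of hydrogen on an aromatic carbon. Compound 3 `Cc1ccc(-n2cc3c(-c4nn(-c5ccccc5)c(-c5ccccc5)c4C#N)nnc(-c4ccccc4)c3n2)cc1` differs from compound 2 as follows: methyl in place of chloro on an aromatic carbon. Within the data shown here, no methyl compound has been measured, so that single step bears on the change only indirectly. Part of a 4.6-fold higher number from compound 1 to compound 2 (0.66 log units; beyond the scatter) is expected to be reversed once chloro leaves, which points to a modest move to a lower number in this assay. The estimated step is a 2.2-fold lower number from compound 2 to compound 3 (0.34 log units; beyond the scatter). For compound 3 the expected value is 20000 nM, with an estimated range of 7000 nM to 50000 nM.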

Compound 3, concentration for 50% growth inhibition: 41600 nM
Estimate against measurement, compound 3: 2.1-fold (0.32 log units) below; the range from low to high includes it.
By their numbers in this assay, from the lowest: compound 1; then compounds 3 and 2 (each within the scatter of the next).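

Chloro and methyl are not separated at this place, on a six-membered aromatic ring of carbon only and para to a large group: the exchange gives a 1.1-fold lower number from compound 2 to compound 3 (0.02 log units; within the scatter) in this assay. Methyl in place of hydrogen gives a 4.4-fold higher number from compound 1 to compound 3 (0.64 log units; beyond the scatter) and chloro in place of hydrogen gives a 4.6-fold higher number from compound 1 to compound 2 (0.66 log units; beyond the scatter), so the move to a higher number from compound 1 is not confined to chloro among these compounds. No measurement is available that would explain this shared shift.

Three compounds cannot show whether any group at this place gives a higher number than hydrogen, or only these two do. An amine, a methoxy group or a carboxylic acid at the same place would test this, and a longer chain would show whether size of the group matters.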